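Bromo for chloro on the hydrazide ring: two iodophenol cores

The source may report more compounds than this note shows. Statements on the series, on what has been measured and on what is new or still open speak of the compounds shown alone.

Compound 1 `O=C(N/N=C/c1cc(I)cc(I)c1O)c1ccc(Cl)cc1` and compound 2 `O=C(N/N=C/c1cc(I)cc(I)c1O)c1ccc(Br)cc1` share one core; compound 3 `O=C(N/N=C/c1cc(I)c(O)c(I)c1)c1ccc(Cl)cc1` and compound 4 `O=C(N/N=C/c1cc(I)c(O)c(I)c1)c1ccc(Br)cc1` share another, and the difference between the two cores is not broken down here. In a functional assay on HepG2 cells (Homo sapiens) for cytotoxicity, with a stated time of 24 h (on this read-out higher numbers stand for weaker inhibition and lower numbers for stronger inhibition), compound 1 gives 14800 nM and compound 2 gives 22300 nM; the change bromo in place of chloro on an aromatic carbon made a 1.5-fold higher number from compound 1 to compound 2 (0.18 log units; within the scatter). In this assay compound 3 reports only a limit, > 100000 nM, as noted in the limit of > 100000 nM in this assay, at which 1 of the 3 values shown sits. The change bromo in place of chloro on an aromatic carbon is the same change in the same place. With compound 3 already at a limit, compound 4 is expected also to sit at a limit, estimated near 150000 nM. The expected step from compound 3 is a step that the limit leaves unreadable from compound 3 to compound 4, which rests on the small measured a 1.5-fold higher number from compound 1 to compound 2 (0.18 log units; within the scatter).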

Compound 4, half-maximal inhibitory concentration: > 50000 nM
Compound 4 ended at the assay's limit; the forecaster's own chance of this, stated with the estimate: 80%; the middle value is on the limit's open side.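

In this assay, compound 3 is only a limit, > 100000 nM. Going by these compounds alone, compound 4 is also only a limit, > 50000 nM, so no step between them can be read. On these data alone, whether bromo in place of chloro changes the number on this core stays open.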